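A few compounds are considered here, and "the series" means these few. Any claim that something is new, unique, unknown or untested is made for them only; others in the source may bear on it.

In a functional assay on HCT-116 cells (Homo sapiens) for antiproliferative activity, with a stated time of 72 h (a lower number here means a stronger inhibitor, a higher number a weaker inhibitor), compound 1 `Nc1ncnn2c([C@@H]3O[C@H](CO)[C@@H](O)[C@H]3O)cc(C#Cc3cccs3)c12` gives 65500 nM. Compound 2 `Cc1ccccc1-c1cc([C@@H]2O[C@H](CO)[C@@H](O)[C@H]2O)n2ncnc(N)c12` returns only a limit of the assay, > 100000 nM, so it has no exact value. Compound 3 `Nc1ncnn2c([C@@H]3O[C@H](CO)[C@@H](O)[C@H]3O)cc(-c3ccsc3)c12` carries thiophen-3-yl in place of the 2-methylphenyl of compound 2 on an aromatic carbon: thiophen-3-yl in place of 2-methylphenyl on an aromatic carbon. Within the data shown here, the one measured step at this same place, an at least 1.5-fold higher number from compound 1 to compound 2 (0.18 log units; that floor lies within the scatter), stays within the scatter and rests on a limit, so it offers weak guidance. A modest step towards a lower number is expected in this assay, an at least 2.5-fold lower number from compound 2 to compound 3 (0.39 log units; beyond the scatter). For compound 3, the estimated value is 40000 nM, with an expected range from 5000 nM to 100000 nM.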

Compound 3, half-maximal inhibitory concentration: 45200 nM
Compound 3: middle estimate off by 1.1-fold (0.05 log units), on the low side; the range from low to high includes it.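

In this assay, among these compounds, thiophen-3-yl on this aromatic carbon gives an at least 2.2-fold lower number from compound 2 to compound 3 (0.34 log units; beyond the scatter) and is the first step at this place to lie beyond the scatter. Compound 2 has only a limit, so that step is a floor and not a true size: the limit of > 100000 nM in this assay, at which 1 of the 3 values shown sits. Replacing the 2-(thiophen-2-yl)ethynyl of compound 1 gives a 1.4-fold lower number from compound 1 to compound 3 (0.16 log units; within the scatter) and leaves the two groups within the scatter of each other. As far as these compounds go, whether an amine or a carboxylic acid on this carbon would lower the number stays open. So does whether a phenyl without the methyl would differ from compound 2.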